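The source may report more compounds than this note shows. Statements on the series, on what has been measured and on what is new or still open speak of the compounds shown alone.

In a functional assay on NCI-H630 cells (Homo sapiens) for cytotoxicity, read by sulforhodamine B assay, with a stated time of 5 days (on this read-out higher numbers stand for weaker inhibition and lower numbers for stronger inhibition), the measured compounds read as follows:

- Compound 1 (`O=C(CCCCCCCc1ccccc1)N[C@H]1CCOC1=O`) reads > 100000 nM as a limit of the assay
- Compound 2 (`O=C(CCCc1ccccc1)N[C@H]1CCOC1=O`) reads > 100000 nM as a limit of the assay
- Compound 3 (`O=C(CCCc1ccccc1)CC(=O)N[C@H]1CCOC1=O`) reads > 100000 nM as a limit of the assay

Compound 1 has no number of its own and stands at the limit of > 100000 nM in this assay, at which 3 of the 3 values shown sit, so no order can be drawn among the three compounds. Compound 4 (`O=C(CCCCCCCCc1ccccc1)N[C@H]1CCOC1=O`) departs from compound 1 in one place: benzyl in place of phenyl on a saturated chain carbon, seven bonds along the chain from a carbonyl carbon and the change is benzyl in place of phenyl on a saturated chain carbon, seven bonds along the chain from a carbonyl carbon. For the measured compounds named here, no measured step gives the size of such a change in this assay so no shift beyond the scatter is expected, and the direction stays open. This expectation rests on compound 1, which gives > 100000 nM as a limit. The expected change is a number no higher from compound 1 to compound 4 (the limit leaves the size open) as an estimate only. For compound 4 the estimated value is 100000 nM with an expected range from 40000 nM to 150000 nM and the assay may well report only a limit again.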

Compound 4, half-maximal inhibitory concentration: > 100000 nM
Compound 4 was reported as a limit; the forecaster's own chance of this, stated with the estimate: 80%; the middle value sits exactly at the limit.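

No step can be read from compound 1 to compound 4, because both values are limits and not numbers: the limit of > 100000 nM in this assay, at which 4 of the 4 values shown sit. The compounds shown leave open how they rank against one another and what change to them, if any, would give a measured number.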